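The source may report more compounds than this note shows. Statements on the series, on what has been measured and on what is new or still open speak of the compounds shown alone.

Measured compounds:

compound 1 `O=C(Nc1cccc(-n2cc(-c3ccncc3)c(-c3cc(O)cc(Cl)c3)n2)c1)Nc1ccc(Cl)c(C(F)(F)F)c1` — 105%
compound 2 `O=C(Nc1cccc(-n2cc(-c3ccncc3)c(-c3cc(O)cc(Cl)c3)n2)c1)Nc1ccc(Cl)c(Cl)c1` — 85%

Of the compounds shown here, two share a core and have been measured in a functional assay on MDA-MB-231 cells (Homo sapiens) for inhibition, read by sulforhodamine B assay, with a stated time of 48 h, tested at 0.1 uM; a lower number here means a stronger effect, a higher number a weaker effect of the compound at the concentration tested. Compound 1 gives 105%, and compound 2 gives 85%. Within the data shown here, compound 1 stands highest of the two, and the step of a number 20 percentage points lower from compound 1 to compound 2 (beyond the scatter) is the only measured step; it comes from a chloro in place of a trifluoromethyl on an aromatic carbon, a change on the other end of the molecule from the one now at issue.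

Compound 3 `COc1cc(Cl)cc(-c2nn(-c3cccc(NC(=O)Nc4ccc(Cl)c(C(F)(F)F)c4)c3)cc2-c2ccncc2)c1` has not yet been measured in this assay. It differs from compound 1 by methyl in place of hydrogen on an oxygen on an aromatic ring. Among the measured compounds shown here, no measured step bears on this change: the single measured step concerns a different part of the shared core, and the hydroxy group itself has not been varied among the measured compounds. With nothing to build on, compound 3 is expected to stay close to compound 1, and the step of a number 5 percentage points lower from compound 1 to compound 3 (within the scatter) is estimated to fall within the usual scatter in either direction. Compound 3 is therefore estimated at 100%, in a range from 80% to 115%.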

Compound 3, a percentage reported as activity, at one concentration (the size of the read-out at that concentration, not a potency): 91%
Beside the measured number, compound 3's estimate is 9 percentage points above it; measured number inside the range.
By their numbers in this assay, from the lowest: compounds 2 and 3 (each within the scatter of the next); then compound 1.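

In this assay, among these compounds, the step of a number 14 percentage points lower from compound 1 to compound 3 (beyond the scatter) is the first reading on the hydroxy group of the 3-chloro-5-hydroxyphenyl ring, and it shows that this position is not silent: methyl in place of hydrogen on that oxygen moves the read-out beyond the scatter, toward a stronger effect at the concentration tested. Among the compounds shown here, the free hydroxy is therefore not needed for the effect seen with compound 3, and the earlier step of a number 20 percentage points lower from compound 1 to compound 2 (beyond the scatter) at the other end of the molecule is no longer the only modest change to have moved the number from compound 1. Nothing available explains why the methoxy compound reads lower than the hydroxy compound.

On these data alone, what remains open is whether the trend continues with a longer chain on the same oxygen, such as ethoxy, or whether an amine or a carboxylic acid at this position would move the number in the same direction. It is also open whether hydroxy to methoxy gives a similar step when chloro rather than trifluoromethyl sits at the far end of the molecule, and a reading at one concentration does not give the potency of any of these compounds.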